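Swapping a Dimethylamino Terminus for Piperidine on the Side Chain

The source may report more compounds than this note shows. Statements on the series, on what has been measured and on what is new or still open speak of the compounds shown alone.

Compound 1 `Cc1cc(NCCN(C)C)nc2ccc(NC(=O)c3ccc(Cl)c(Cl)c3)cc12` gives 1.47 in a physicochemical assay for lipophilicity, at pH 7.4 (a lower number here means a more polar compound, a higher number a more lipophilic compound), the lowest of the three numbers recorded; its nearest neighbour is compound 2 `Cc1cc(NCCN2CCN(C)CC2)nc2ccc(NC(=O)c3ccc(Cl)c(Cl)c3)cc12` with 1.73, while compound 3 `CCN1CCN(c2cc(C)c3cc(NC(=O)c4ccc(Cl)c(Cl)c4)ccc3n2)CC1` stands furthest away at 3.67. The step of a number 0.26 log units higher from compound 1 to compound 2 (within the scatter) is the only one at the same place as the change now considered, whereas a number 2.20 log units higher from compound 1 to compound 3 (beyond the scatter) and a number 1.94 log units higher from compound 2 to compound 3 (beyond the scatter) both replace the whole side chain on an aromatic carbon and say little about a change at the chain terminus. Compound 4 `Cc1cc(NCCN2CCCCC2)nc2ccc(NC(=O)c3ccc(Cl)c(Cl)c3)cc12` differs from compound 1 as follows: piperidin-1-yl in place of dimethylamino on a saturated chain carbon, two bonds along the chain from a nitrogen on an aromatic ring. The entering group carries three more carbon atoms than the one it replaces, and a change of that kind is expected to lift the number by a moderate amount, since the related step of a number 0.26 log units higher from compound 1 to compound 2 (within the scatter) added a ring without such a gain and stayed within the scatter. Compound 4 is therefore estimated at 2.6, in the range 2 to 3.2, a step of a number 1.13 log units higher from compound 1 to compound 4 (beyond the scatter).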

Compound 4, distribution coefficient: 2.72
Compound 4: middle estimate off by 0.12 log units, on the low side, and the stated range covers the measured number.
By their numbers in this assay, from the lowest: compounds 1 and 2 (each within the scatter of the next); then compound 4; then compound 3.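

In this assay, the end of the side chain proves able to move the number well beyond the scatter: piperidin-1-yl in place of dimethylamino gives a number 1.25 log units higher from compound 1 to compound 4 (beyond the scatter), whereas the earlier change at this place gave only a number 0.26 log units higher from compound 1 to compound 2 (within the scatter). Bringing a ring to this place does not by itself fix the number, since piperidin-1-yl in place of 4-methylpiperazin-1-yl gives a number 0.99 log units higher from compound 2 to compound 4 (beyond the scatter). The chain-linked piperidine still does not reach the directly attached ring, as (2-(piperidin-1-yl)ethyl)amino in place of 4-ethylpiperazin-1-yl on an aromatic carbon gives a number 0.95 log units lower from compound 3 to compound 4 (beyond the scatter).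

On these data alone, whether the rise follows the carbon count or the ring itself stays open, and a pyrrolidin-1-yl or morpholin-4-yl terminus, or a longer chain, would bear on that. Nothing available explains the size of these steps.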